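The source may hold more compounds than are shown below. What is called first, only, known or untested is meant among the compounds shown, and "the series" means these compounds.

Working notes on the series. Of the compounds shown here, two have been measured so far in an assay on isolated protein for inhibition of ubiquitin carboxyl-terminal hydrolase 7 (Homo sapiens), with stated times of 30 min and 2 h; a higher number here means a weaker inhibitor, a lower number a stronger inhibitor. Compound 1 `Cn1nc2c(=O)n(CC3(O)CCN(Cc4ccc(-c5ccco5)cc4Cl)CC3)cnc2c1-c1ccc(OC(F)F)cc1` gives 179 nM in this assay. Compound 2 `Cn1nc2c(=O)n(CC3(O)CCN(Cc4ccc(-c5ccsc5)cc4Cl)CC3)cnc2c1-c1ccc(CN)cc1` gives 59.5 nM in this assay and so holds the lowest number of the two; the number for compound 1 is higher by a margin that lies beyond the usual scatter. Among the measured compounds shown here, compound 1 and compound 2 differ in more than one place, so the two values alone are what is known, with no single step counted between them.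

The next compound to be measured is compound 3 `Cn1nc2c(=O)n(CC3(O)CCN(Cc4ccc(-n5ccnc5)cc4Cl)CC3)cnc2c1-c1ccc(CN)cc1`, which differs from compound 2 in one place: 1H-imidazol-1-yl in place of thiophen-3-yl on an aromatic carbon. For the measured compounds named here, no measured pair shows this change, so the expectation rests only on compound 2 and its value 59.5 nM in this assay. The step from compound 2 to compound 3 is expected to be small, toward a weaker inhibitor, at the edge of the scatter: a 1.7-fold higher number from compound 2 to compound 3 (0.23 log units; within the scatter). Compound 3 is therefore estimated at 100 nM in this assay, with a likely range from 35 nM to 300 nM.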

Compound 3, half-maximal inhibitory concentration: 228 nM
For compound 3 the middle estimate is 2.3-fold (0.36 log units) below the measured one, within the range that was stated.
By their numbers in this assay, from the lowest: compound 2; then compounds 1 and 3 (each within the scatter of the next).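

At the place para to a large group and meta to a chloro group, 1H-imidazol-1-yl in place of thiophen-3-yl gives a 3.8-fold higher number from compound 2 to compound 3 (0.58 log units; beyond the scatter) in this assay, a modest step that shows this position is not indifferent to the choice between these two five-membered aromatic rings. Both groups have the same number of heavy atoms, no hydrogen-bond donors and no net charge, so the step goes with a change in the ring itself: sulfur leaves, two nitrogens enter, and the count of hydrogen-bond acceptors rises. No measurement in hand accounts for the step, and the data cannot say which of these differences matters.

Among the compounds shown here, compound 1, which carries a furan ring at this position, differs from compound 2 and from compound 3 in more than one place, so no step to it can be read. On these data alone, it remains open whether a phenyl ring, a pyridine ring, a carbon-linked imidazole or a saturated amine such as morpholine at this position would stay close to compound 2 or fall nearer to compound 3.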